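Branching the pentyl chain of compound 3

The compounds below may be only part of what the source reports. "The series", "measured", "known", "first", "only" and "open" are said of these compounds alone.

In a functional assay on A549 cells (Homo sapiens) for antiproliferative activity, read by MTT assay, with a stated time of 48 h (a higher number here means a weaker inhibitor, a lower number a stronger inhibitor), compound 1 (`Cc1ccc(Nc2ccc3c(c2)C(O)(CCC(C)C)C(=O)N3)cc1`) gives 12500 nM. Compound 2 (`CC(C)CCC1(O)C(=O)Nc2ccc(Nc3ccc(Cl)cc3)cc21`) gives 2700 nM, and compound 3 (`CCCCCC1(O)C(=O)Nc2ccc(Nc3ccc(C(F)(F)F)cc3)cc21`) gives 2200 nM. Compound 3 thus sits within the scatter of compound 2, and the numbers of both lie clearly under that of compound 1.

Compound 4 (`CC(C)CCC1(O)C(=O)Nc2ccc(Nc3ccc(C(F)(F)F)cc3)cc21`) has isopropyl in place of propyl on a saturated chain carbon, two bonds along the chain from a saturated ring carbon, so pentyl becomes isopentyl (isopropyl in place of propyl on a saturated chain carbon, two bonds along the chain from a saturated ring carbon). For the measured compounds named here, the only measured step, a 4.6-fold lower number from compound 1 to compound 2 (0.67 log units; beyond the scatter), is modest, but it swaps chloro in place of methyl on an aromatic carbon and leaves the chain untouched. Going by the values given here, no measured step changes the chain itself, so the data offer only indirect guidance. Compound 2 already carries isopentyl and gives 2700 nM, which is within the scatter of the pentyl compound 3, though the two also differ on the aromatic group. The expected change is therefore none beyond the scatter, an estimated 1.0-fold higher number from compound 3 to compound 4 (0.02 log units; within the scatter). Compound 4 is expected at 2300 nM, with an estimated range of 1200 nM to 4500 nM.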

Compound 4, half-maximal inhibitory concentration: 4200 nM
For compound 4 the middle estimate is 1.8-fold (0.26 log units) below the measured one; low and high end bracket the measured number.
By their numbers in this assay, from the lowest: compounds 3, 2 and 4 (each within the scatter of the next); then compound 1.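

In this assay, for the compounds shown here, the change from pentyl to isopentyl gives a 1.9-fold higher number from compound 3 to compound 4 (0.28 log units; within the scatter), the first direct reading at this chain position, and it does not separate the branched chain from the straight one. With isopentyl held constant, the aromatic group can now be compared across three compounds: trifluoromethyl in place of chloro gives a 1.6-fold higher number from compound 2 to compound 4 (0.19 log units; within the scatter), whereas trifluoromethyl in place of methyl gives a 3.0-fold lower number from compound 1 to compound 4 (0.47 log units; beyond the scatter), so compound 1 stands apart from both compound 2 and compound 4. No measured evidence shown here accounts for these steps.

Going by these compounds, whether a longer chain, a cyclopropylmethyl group or a chain bearing a hydroxyl group would behave as pentyl and isopentyl do remains open. On these data alone, it is also open whether the chain change would read the same with chloro or methyl on the aromatic ring.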